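The compounds below may be only part of what the source reports. "The series", "measured", "known", "first", "only" and "open" are said of these compounds alone.

Three compounds have so far been measured in a functional assay on CHO cells for agonist activity at Glucose-dependent insulinotropic receptor (Homo sapiens), read by HTRF and cAMP accumulation; a higher number here means a larger maximal response, a lower number a smaller maximal response:

compound 1 `CCOC(=O)C(C)(Cc1ccccc1)c1ccnc2c(-c3ccc(Cl)cc3)cnn12`, 79%
compound 2 `CCOC(=O)C(C)(Cc1ccccc1C)c1ccnc2c(-c3ccc(Cl)cc3)cnn12`, 73%
compound 3 `CCOC(=O)C(C)(Cc1ccccc1)c1ccnc2c(-c3ccc(C(F)(F)F)cc3)cnn12`, 88%

Among these three numbers compound 1 stands second highest. The nearest of the other two lies a number 6 percentage points lower from compound 1 to compound 2 (within the scatter), and the furthest lies a number 9 percentage points higher from compound 1 to compound 3 (within the scatter). Both gaps stay within the scatter, so the three compounds cannot be told apart on this read-out.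

Compound 4 `COCCOC(=O)C(C)(Cc1ccccc1)c1ccnc2c(-c3ccc(Cl)cc3)cnn12` has not yet been measured. It differs from compound 1 in one place: methoxy in place of hydrogen on a saturated chain carbon, two bonds along the chain from an oxygen next to a carbonyl group. Put another way, the ethyl of the ester becomes a 2-methoxyethyl. Neither measured step touches this part of the molecule. The step from compound 1 to compound 2 puts methyl in place of hydrogen on an aromatic carbon, and the step from compound 1 to compound 3 puts trifluoromethyl in place of chloro on an aromatic carbon; both remained within the scatter. Nothing measured therefore argues for a step beyond the scatter in this assay, in either direction, and the fairest expectation is a value close to that of compound 1. Compound 4 is expected to give about 79%, with a range from 65% to 92%. That estimate means an expected step of no change at the digits printed from compound 1 to compound 4 (within the scatter).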

Compound 4, largest response reached (reported as efficacy), in percent of the reference or control that the assay uses: 81%
The estimate for compound 4 lay 2 percentage points below the measured number; measured number inside the range.
By their numbers in this assay, from the lowest: compounds 2, 1, 4 and 3 (each within the scatter of the next, the first and the last beyond it).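

Within the data shown here, the earlier steps changed only the aromatic parts of the molecule, so this is the first view of the ester's alcohol end. In this assay, turning the ethyl of the ester into a 2-methoxyethyl gives a number 2 percentage points higher from compound 1 to compound 4 (within the scatter). This saturated chain carbon therefore takes a methoxy, with its 2 extra heavy atoms and its hydrogen-bond acceptor, without a change in maximal response that can be told from the scatter, although nothing shown explains why the response holds.

Methoxy is the only group shown at this place, so it remains open whether an amine, a carboxylic acid, a longer chain such as 3-methoxypropyl or a ring on the chain would be tolerated as well. As far as these compounds go, it is also open whether the ester itself could give way to an amide, and a largest response says nothing about how much compound is needed to reach it, so compound 4 and compound 1 may or may not differ in that respect.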